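The source may report more compounds than this note shows. Statements on the series, on what has been measured and on what is new or still open speak of the compounds shown alone.

In a functional assay on HT-1080 cells (Homo sapiens) for cytotoxicity, read by MTT assay, with a stated time of 72 h (on this read-out lower numbers stand for stronger inhibition and higher numbers for weaker inhibition), compound 1 `COc1cccc(/C=C2\CCC/C(=C\c3ccccc3Cl)C2=O)c1OC` gives 11700 nM and compound 2 `COc1cccc(/C=C2\CCC/C(=C\c3cccc(Cl)c3Cl)C2=O)c1OC` gives 19300 nM while compound 3 `COc1ccc(/C=C2\CCC/C(=C\c3cccc(OC)c3OC)C2=O)cc1OC` gives 6400 nM as its number. That number lies within the scatter of compound 1 and lower than compound 2 by more than the scatter. Compound 4 `COc1cc(/C=C2\CCC/C(=C\c3cccc(OC)c3OC)C2=O)ccc1O` carries hydrogen in place of methyl on an oxygen on an aromatic ring, methoxy to hydroxy, and hydrogen in place of methyl on an oxygen on an aromatic ring counts that difference from compound 3. Within the data shown here, the only measured step of a 1.6-fold higher number from compound 1 to compound 2 (0.22 log units; within the scatter) stays within the scatter, yet it is chloro in place of hydrogen on an aromatic carbon, so it bears only loosely. Among the measured compounds shown here, no measured pair shows methoxy to hydroxy, so no step beyond the scatter is expected in this assay and no direction is favoured. The estimated step of a 1.2-fold lower number from compound 3 to compound 4 (0.07 log units; within the scatter) stays within the scatter. Compound 4 is therefore expected near 5500 nM within an estimated range from 2000 nM to 15000 nM overall.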

Compound 4, half-maximal inhibitory concentration: 5900 nM
The estimate for compound 4 lay 1.1-fold (0.03 log units) below the measured number, within the range that was stated.
By their numbers in this assay, from the lowest: compounds 4, 3, 1 and 2 (each within the scatter of the next, the first and the last beyond it).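

In this assay, among these compounds, the change from methoxy to hydroxy on the aromatic ring gives a first reading at this oxygen (a 1.1-fold lower number from compound 3 to compound 4 (0.04 log units; within the scatter)), so loss of this methyl leaves the number within the scatter. With 4-hydroxy-3-methoxyphenyl in place of 2,3-dichlorophenyl the shift passes the scatter (a 3.3-fold lower number from compound 2 to compound 4 (0.51 log units; beyond the scatter)), whereas in place of 2-chlorophenyl it does not (a 2.0-fold lower number from compound 1 to compound 4 (0.30 log units; within the scatter)). No supporting evidence explains these numbers.

The compounds shown leave open how a longer chain on this oxygen, or an amine in place of the hydroxy, would read in this assay on this core.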